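The source may hold more compounds than are shown below. What is called first, only, known or untested is meant among the compounds shown, and "the series" means these compounds.

Compound 1 `CCCCCCc1cn(C(c2ccccc2)c2cc3cc(Br)ccc3nc2OC)nn1`: 6.08%
Compound 2 `CCCCCCCCc1cn(C(c2ccccc2)c2cc3cc(Br)ccc3nc2OC)nn1`: 12.1%
Compound 3 `COc1nc2ccc(Br)cc2cc1C(c1ccccc1)n1cc(-c2ccc(F)cc2)nn1`: 14.9%

In an ADME assay on PANC-1 cells (Homo sapiens) for cytotoxicity, read by sulforhodamine B assay, with a stated time of 48 h, tested at 10 uM (on this read-out higher numbers stand for more inhibition at the one concentration tested (going by the name of the read-out) and lower numbers for less inhibition), compound 1 gives 6.08%, the lowest of the three numbers. The closer of the other two numbers sits a number 6 percentage points higher from compound 1 to compound 2 (within the scatter), and the farther one sits a number 8.8 percentage points higher from compound 1 to compound 3 (within the scatter). All three compounds therefore sit in a band that the scatter of this assay does not separate.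

Compound 4 `COc1nc2ccc(Br)cc2cc1C(c1ccccc1)n1cc(C2CC2)nn1` differs from compound 1 in one place: cyclopropyl in place of hexyl on an aromatic carbon. Going by the values given here, no measured step swaps hexyl for cyclopropyl, but two measured steps change the group on that same aromatic carbon. Going from compound 1 to compound 3, where 4-fluorophenyl replaces hexyl, the number moves a number 8.8 percentage points higher from compound 1 to compound 3 (within the scatter); going from compound 2 to compound 3, where 4-fluorophenyl replaces octyl, it moves a number 2.8 percentage points higher from compound 2 to compound 3 (within the scatter). Lengthening the chain itself, a number 6 percentage points higher from compound 1 to compound 2 (within the scatter), also stays within the scatter. A small ring in place of the hexyl chain is thus expected to leave the read-out in this assay much where it is, with no step beyond the scatter in either direction; the step from compound 1 to compound 4 is estimated at a number 3.9 percentage points higher from compound 1 to compound 4 (within the scatter). For compound 4 the expected value in this assay is 10%, with a range from 0% to 25%.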

Compound 4, a percentage reported as inhibition, at one concentration (the size of the read-out at that concentration, not a potency): 21.8%
Estimate against measurement, compound 4: 11.8 percentage points below; the measured number falls inside the stated range.
By their numbers in this assay, from the lowest: compounds 1, 2, 3 and 4 (each within the scatter of the next, the first and the last beyond it).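

Cyclopropyl in place of hexyl on the aromatic carbon of the five-membered ring is the first change at this position that separates two compounds in this assay, with a number 15.7 percentage points higher from compound 1 to compound 4 (beyond the scatter) as its size. The same ring does not stand apart from the other two groups at this carbon: in place of 4-fluorophenyl it gives a number 6.9 percentage points higher from compound 3 to compound 4 (within the scatter) and in place of octyl it gives a number 9.7 percentage points higher from compound 2 to compound 4 (within the scatter) as the step, so the position is shown to matter only across the full span of the four compounds, between hexyl and cyclopropyl. Nothing at hand says why these two groups read differently.

Going by these compounds, whether the ring itself or simply the smaller group goes with the higher number stays open, and a propyl chain, with the carbon count of cyclopropyl but no ring, would bear on that directly. Also open, on these data alone, is how a cyclobutyl ring, or a chain ending in an amine or a carboxylic acid, would read at this same carbon on the shared core.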